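A Fluorine-for-Hydrogen Swap on Two Kinase Scaffolds

The source may report more compounds than this note shows. Statements on the series, on what has been measured and on what is new or still open speak of the compounds shown alone.

Two pairs of compounds share one small change: a fluorine atom replacing a hydrogen atom on a benzene ring. Compound 1 `c1ccc(-[n+]2c[nH]c3ncncc32)cc1` and compound 2 `Fc1ccc(-[n+]2c[nH]c3ncncc32)cc1` belong to one core; compound 3 `c1ccc(Cn2cnc3c(Sc4ccccc4)ncnc32)cc1` and compound 4 `Fc1ccc(Cn2cnc3c(Sc4ccccc4)ncnc32)cc1` belong to another, and the difference between the two cores is not broken down here.

In an assay on isolated protein for inhibition of Rho-associated protein kinase 1 (Homo sapiens), tested at 30 uM (on this read-out lower numbers stand for less inhibition and higher numbers for more inhibition at the one concentration tested (going by the name of the read-out)), compound 1 gives 0%, and compound 2 gives 2%. The change between them, (fluoro in place of hydrogen on an aromatic carbon), produced a number 2 percentage points higher from compound 1 to compound 2 (within the scatter). In this assay compound 3 gives 1%, close to the other two.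

Compound 4 carries the same kind of change relative to compound 3, (fluoro in place of hydrogen on an aromatic carbon). The surroundings differ a little: in the first pair the fluoro sits para to a group of 9 heavy atoms, in the second para to a large group. Because compound 1 and compound 2 showed only a number 2 percentage points higher from compound 1 to compound 2 (within the scatter), the expected step is no change at the digits printed from compound 3 to compound 4 (within the scatter). Compound 4 is therefore estimated at 1%, most likely between -5% and 8%.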

Compound 4, a percentage reported as inhibition, at one concentration (the size of the read-out at that concentration, not a potency): 2%
Compound 4: the middle estimate sits 1 percentage points below what was measured; low and high end bracket the measured number.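

In this assay the swap of hydrogen for fluoro on the second core gives a number 1 percentage points higher from compound 3 to compound 4 (within the scatter) on the benzyl side of the molecule. Set beside the earlier pair, the same change reads alike on both cores: the same change on two cores in this assay, a number 2 percentage points higher (within the scatter) from compound 1 to compound 2 and a number 1 percentage points higher (within the scatter) from compound 3 to compound 4, 1 percentage points apart, within the scatter of two such steps. Among these compounds, this agreement shows only that the swap stays within the scatter on both cores; all four compounds lie near the bottom of the scale, with compound 4 at 2% in this company, so it does not show that the change would carry over in the same way to a compound that inhibits the enzyme clearly.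

The compounds shown leave open whether another group in the same place on the ring, such as an amine, a carboxylic acid or a longer chain, would move the number beyond the scatter. They also leave open how the fluoro swap would read on a core that starts from a clearly higher number.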